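The compounds below may be only part of what the source reports. "The series", "measured", "known", "first", "only" and "open" are said of these compounds alone.

Measured in a functional assay on HeLa cells (Homo sapiens) for antiproliferative activity; a lower number here means a stronger inhibitor, a higher number a weaker inhibitor:
Compound 1 `C=CCO/N=C/c1c(N)ncnc1Oc1ccc2[nH]c(C)cc2c1F`: 42 nM
Compound 2 `Cc1cc2c(F)c(Oc3ncnc(N)c3/C=N/OCCO)ccc2[nH]1`: 406 nM
Compound 3 `Cc1cc2c(F)c(Oc3ncnc(N)c3/C=N/OCCCO)ccc2[nH]1`: 362 nM

Compound 2 sits in the upper, weaker part of this small set. Its nearest neighbour cannot be told apart from it, with a 1.1-fold lower number from compound 2 to compound 3 (0.05 log units; within the scatter). The clear gap lies on the other side, with a 9.7-fold higher number from compound 1 to compound 2 (0.99 log units; beyond the scatter).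

Compound 4 `COCCO/N=C/c1c(N)ncnc1Oc1ccc2[nH]c(C)cc2c1F` has not yet been measured. It differs from compound 2 by a single change: methyl in place of hydrogen on an oxygen on a saturated carbon. This is methyl in place of hydrogen on an oxygen on a saturated carbon, so 2-hydroxyethyl becomes 2-methoxyethyl.

For the measured compounds named here, no measured step makes exactly this change, so the evidence is indirect. The chains of compound 2 and compound 3 both end in hydroxy, and both numbers lie clearly above that of compound 1, whose chain ends in vinyl. The second of those gaps is an 8.6-fold higher number from compound 1 to compound 3 (0.94 log units; beyond the scatter). Compound 4 keeps the oxygen but loses the hydroxy hydrogen, so a partial return towards compound 1 seems a reasonable expectation, though the data cannot confirm it.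

The expected change is a 2.9-fold lower number from compound 2 to compound 4 (0.46 log units; beyond the scatter), a move to a lower number and so a stronger inhibitor. For compound 4 the estimated value is 140 nM, with an expected range from 45 nM to 420 nM.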

Compound 4, half-maximal inhibitory concentration: 308 nM
Beside the measured number, compound 4's estimate is 2.2-fold (0.34 log units) below it; the range from low to high includes it.
By their numbers in this assay, from the lowest: compound 1; then compounds 4, 3 and 2 (each within the scatter of the next).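

In this assay, placing methyl on the oxygen at the end of the chain turns 2-hydroxyethyl into 2-methoxyethyl, yet this step stays within the scatter (a 1.3-fold lower number from compound 2 to compound 4 (0.12 log units; within the scatter)), so removing the hydroxy hydrogen does not bring back the stronger number seen with the vinyl-ended chain of compound 1. Compound 4 also cannot be told apart from compound 3 (a 1.2-fold lower number from compound 3 to compound 4 (0.07 log units; within the scatter)), while the gap to compound 1 remains beyond the scatter (a 7.3-fold higher number from compound 1 to compound 4 (0.87 log units; beyond the scatter)), which places all three chains ending in an oxygen group on the weaker side of compound 1 in this small set. Nothing available here gives a measured reason for this grouping.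

The compounds shown leave open whether the vinyl group itself matters or whether any chain without an oxygen near its end would match compound 1, a question that a plain propyl chain could help to settle. They also leave open how an amine or a carboxylic acid at the end of the chain, or a longer chain ending in methoxy, would compare.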